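Urea series: outlook for compound 4

The source may hold more compounds than are shown below. What is called first, only, known or untested is meant among the compounds shown, and "the series" means these compounds.

Measured in a functional assay on 786-0 cells (Homo sapiens) for inhibition, read by sulforhodamine B assay, with a stated time of 48 h, tested at 10 uM; a lower number here means a stronger effect, a higher number a weaker effect of the compound at the concentration tested:
compound 1 `COc1cc2cc(Oc3ccc(NC(=O)Nc4ccc(C)cc4)cc3)c(C)nc2cc1OC` gives 126%
compound 2 `COc1cc2cc(Oc3ccc(NC(=O)Nc4ccc(C(F)(F)F)cc4)cc3)c(C)nc2cc1OC` gives 74.9%
compound 3 `COc1cc2cc(Oc3ccc(NC(=O)Nc4cccc(C(F)(F)F)c4)cc3)c(C)nc2cc1OC` gives 15.1%

Compound 3 stands lowest of the three numbers; its nearest neighbour is compound 2, and the gap is a number 59.8 percentage points lower from compound 2 to compound 3 (beyond the scatter). The step of a number 110.9 percentage points lower from compound 1 to compound 3 (beyond the scatter) is larger still, and a number 51.1 percentage points lower from compound 1 to compound 2 (beyond the scatter) lies between them. Compound 4 `COc1cc2cc(Oc3ccc(NC(=O)Nc4ccc(Cl)c(Cl)c4)cc3)c(C)nc2cc1OC` differs from compound 3 by 3,4-dichlorophenyl in place of 3-(trifluoromethyl)phenyl on an amide-type nitrogen. Going by the values given here, no measured step bears directly on this exchange: the two trifluoromethyl steps describe a move between aryl groups and a change of substituent, not the entry of two chlorine atoms. An estimate therefore rests on compound 3 alone, with a wide range, and the expected step is a number 6.9 percentage points higher from compound 3 to compound 4 (within the scatter), close to none. Compound 4 is estimated at 22%, between 5% and 65%.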

Compound 4, a percentage reported as activity, at one concentration (the size of the read-out at that concentration, not a potency): 20.3%
Beside the measured number, compound 4's estimate is 1.7 percentage points above it; the range from low to high includes it.
By their numbers in this assay, from the lowest: compounds 3 and 4 (each within the scatter of the next); then compound 2; then compound 1.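

In this assay the 3,4-dichlorophenyl group on the amide-type nitrogen gives a number 5.2 percentage points higher from compound 3 to compound 4 (within the scatter) and so holds the low number of the 3-(trifluoromethyl)phenyl group, showing that this level is not tied to trifluoromethyl. Compound 4 also goes against any link between a group named at 4 and a high number, with a number 54.6 percentage points lower from compound 2 to compound 4 (beyond the scatter) and a number 105.7 percentage points lower from compound 1 to compound 4 (beyond the scatter) as its steps. Nothing available explains these differences. As far as these compounds go, whether 3-chlorophenyl alone keeps this level remains open. So does the effect of an amine or a carboxylic acid on this aryl group.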